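Removing a chlorine from a weakly acting cyclic amidrazone

This account rests on a few compounds, and the source may have more. Where it says the series, first, only, none or still open, it means among the compounds named here.

Of the compounds shown here, three have been tested in a functional assay on T47D cells (Homo sapiens) for cytotoxicity, with a stated time of 72 h, tested at 10 ug/mL; on this read-out lower numbers stand for a weaker effect and higher numbers for a stronger effect at the one concentration tested. Compound 1 `Cc1ccc(N2CCN/C2=N\N)cc1` gives 12%. Compound 2 `N=c1c(=O)[nH]nc2n1CCN2c1ccccc1Cl` gives 0%. Compound 3 `N/N=C1\NCCN1c1cccc(Cl)c1` gives 5%. All three numbers are small, and compound 3 sits among the other two: compound 2 lies a few points lower and compound 1 a few points higher, and both of those gaps fall within the usual scatter of repeated measurements. On these numbers, then, the three compounds cannot be told apart, and none of them shows a marked effect at the single concentration tested.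

Compound 4 `N/N=C1\NCCN1c1ccccc1` has not yet been measured. It differs from compound 3 in one place: hydrogen in place of chloro on an aromatic carbon. Among the measured compounds shown here, since no pair of measured compounds shows a step beyond the scatter, there is no basis for expecting this change to move the number in either direction.

The step of no change at the digits printed from compound 3 to compound 4 (within the scatter) is therefore expected to be no larger than the scatter. Compound 4 is estimated at 5% in this assay, with a likely range from 0% to 15%.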

Compound 4, a percentage reported as inhibition, at one concentration (the size of the read-out at that concentration, not a potency): 0%
Compound 4: middle estimate off by 5 percentage points, on the high side, and the stated range covers the measured number.
By their numbers in this assay, from the lowest: compounds 2, 4, 3 and 1 (each within the scatter of the next, the first and the last beyond it).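

In this assay hydrogen in place of chloro gives a number 5 percentage points lower from compound 3 to compound 4 (within the scatter) and so the chloro on this aromatic carbon is not shown to matter for the small effect seen. Hydrogen in place of methyl on an aromatic carbon gives a number 12 percentage points lower from compound 1 to compound 4 (beyond the scatter) and this is the first step in the series to clear the scatter, though only a modest one. Nothing available here explains either step.

The compounds shown say nothing about how an amine, a methoxy group or a carboxylic acid on this aromatic carbon would read, so it remains open whether any group here can give a marked effect. They also leave open whether a longer chain in place of the methyl would carry the step from compound 1 any further.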